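Lengthening an Alkoxy Chain by One Carbon

The source may report more compounds than this note shows. Statements on the series, on what has been measured and on what is new or still open speak of the compounds shown alone.

Three measured compounds share a core. Compound 1 `CCCCCCc1ccc(-c2c(C)[nH]c(=O)n2C)cc1` gives 9000 nM in a functional assay on brain (Rattus norvegicus, strain Wistar) for inhibition; on this read-out higher numbers stand for weaker inhibition and lower numbers for stronger inhibition. Compound 2 `CCCCCCOc1ccc(-c2c(C)[nH]c(=O)n2C)cc1` gives 7300 nM in this assay, and compound 3 `CCCCCCCc1ccc(-c2c(C)[nH]c(=O)n2C)cc1` gives 8400 nM. The two cores differ by hexyloxy in place of hexyl on an aromatic carbon, a step of a 1.2-fold lower number from compound 1 to compound 2 (0.09 log units; within the scatter). Within the first core, the change methyl in place of hydrogen on a saturated chain carbon, six bonds along the chain from an aromatic carbon made a step of a 1.1-fold lower number from compound 1 to compound 3 (0.03 log units; within the scatter). Compound 4 `CCCCCCCOc1ccc(-c2c(C)[nH]c(=O)n2C)cc1` is not yet measured; it differs from compound 2 by methyl in place of hydrogen on a saturated chain carbon, six bonds along the chain from an oxygen on an aromatic ring. This is the same kind of change as that from compound 1 to compound 3, but here the chain runs from an oxygen on an aromatic ring rather than from an aromatic carbon. In this assay the expected step is a 1.1-fold lower number from compound 2 to compound 4 (0.05 log units; within the scatter), resting on the small step of a 1.1-fold lower number from compound 1 to compound 3 (0.03 log units; within the scatter). Compound 4 is therefore estimated at 6500 nM, expected between 3000 nM and 14000 nM.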

Compound 4, half-maximal inhibitory concentration: 5700 nM
Compound 4: middle estimate off by 1.1-fold (0.06 log units), on the high side; the range from low to high includes it.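

Methyl in place of hydrogen on the hexyloxy chain makes a 1.3-fold lower number from compound 2 to compound 4 (0.11 log units; within the scatter) in this assay, so neither this step nor its earlier counterpart on the other core stands clear of the scatter. Among these compounds, the pair shows only that this change looks alike on both cores; it does not show that the added carbon truly alters inhibition on either one. Set side by side, the two steps agree: the same change on two cores in this assay, a 1.1-fold lower number (0.03 log units; within the scatter) from compound 1 to compound 3 and a 1.3-fold lower number (0.11 log units; within the scatter) from compound 2 to compound 4, 1.2-fold (0.08 log units) apart, within the scatter of two such steps

The compounds shown leave open what a longer chain such as octyl or octyloxy, or a shorter one such as butyl or butoxy, would do on these two cores. Also open, as far as these compounds go, is whether a chain carrying an amine or a carboxylic acid would give a step beyond the scatter.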